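The compounds below may be only part of what the source reports. "The series", "measured", "known", "first", "only" and "open" are said of these compounds alone.

Compound 1 `CCOC(=O)c1cc(-c2cc(OC)c(OC)c(OC)c2)c(-c2ccc(OC)c([N+](=O)[O-])c2)s1` and compound 2 `COc1ccc(-c2sc(C(=O)O)cc2-c2cc(OC)c(OC)c(OC)c2)cc1[N+](=O)[O-]` share one core and differ only by hydrogen in place of ethyl on an oxygen next to a carbonyl group. In a functional assay on HT-1080 cells (Homo sapiens) for antiproliferative activity, read by MTT assay, with a stated time of 72 h (on this read-out lower numbers stand for stronger inhibition and higher numbers for weaker inhibition), compound 1 gives 12700 nM, while compound 2 gives 37200 nM, which amounts to a 2.9-fold higher number from compound 1 to compound 2 (0.47 log units; beyond the scatter). Compound 3 `CCOC(=O)c1cc(-c2ccc(OC)cc2)c(-c2cc(OC)c(OC)c(OC)c2)s1` rests on a core whose difference from the core of compound 1 is not broken down here; in this assay compound 3 gives 7630 nM. Compound 4 `COc1ccc(-c2cc(C(=O)O)sc2-c2cc(OC)c(OC)c(OC)c2)cc1` differs from compound 3 by hydrogen in place of ethyl on an oxygen next to a carbonyl group, the same change that separates compound 1 from compound 2, made at the same place. Because the earlier step of a 2.9-fold higher number from compound 1 to compound 2 (0.47 log units; beyond the scatter) was modest yet beyond the scatter, compound 4 is expected to show a step of similar size, a 2.8-fold higher number from compound 3 to compound 4 (0.44 log units; beyond the scatter), in this assay. Compound 4 is therefore estimated at 21000 nM, with a likely range from 9000 nM to 50000 nM.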

Compound 4, half-maximal inhibitory concentration: 5810 nM
Compound 4: the middle estimate sits 3.6-fold (0.56 log units) above what was measured, and the stated range ends above it.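

In this assay, putting hydrogen in place of ethyl on the oxygen gives a 1.3-fold lower number from compound 3 to compound 4 (0.12 log units; within the scatter). On the core of compound 3, the ethoxycarbonyl and carboxy forms therefore cannot be told apart, and the size of the change does not carry over from one core to the other: the same change on two cores in this assay, a 2.9-fold higher number (0.47 log units; beyond the scatter) from compound 1 to compound 2 and a 1.3-fold lower number (0.12 log units; within the scatter) from compound 3 to compound 4, 3.8-fold (0.59 log units) apart, beyond the scatter of two such steps. Within the data shown here, this rests on only two pairs and does not show which difference between the cores matters or how the change would behave on a further core.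

The compounds shown leave open whether methyl or a longer chain in place of ethyl would behave as on the core of compound 1 or as on the core of compound 3. They also leave open how an amide or a nitrile in place of the ethoxycarbonyl group would fare on either core.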